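A Nitrophenyl Carbamoyl Group on the Ring Nitrogen

This account rests on a few compounds, and the source may have more. Where it says the series, first, only, none or still open, it means among the compounds named here.

Of the compounds shown here, two built on a shared core have been measured in an assay for binding affinity to Apoptosis regulator Bcl-2 (Homo sapiens), read by fluorescence polarization, with stated times of 30 min and 20 min, tested at 100 uM; on this read-out higher numbers stand for more inhibition at the one concentration tested (going by the name of the read-out) and lower numbers for less inhibition. Compound 1 `COc1ccc(Oc2ccc([N+](=O)[O-])cc2-c2ccsc2S(=O)(=O)N2CCN(C(=S)Nc3ccc(Cl)cc3)CC2)cc1OC` gives 18% in this assay, and compound 2 `COc1ccc(Oc2ccccc2-c2ccsc2S(=O)(=O)N2CCN(C(=O)Nc3cc(C(F)(F)F)cc(C(F)(F)F)c3)CC2)cc1OC` gives 23%. The two numbers lie within the usual scatter of each other, so neither can be set apart from the other; compound 1 simply gives the smaller of the two readings, with compound 2 the nearest and only comparison available.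

Compound 3 `COc1ccc(Oc2ccc([N+](=O)[O-])cc2-c2ccsc2S(=O)(=O)N2CCN(C(=O)Nc3ccc([N+](=O)[O-])cc3)CC2)cc1OC` has not been measured. It differs from compound 1 in one place: a group of 12 heavy atoms (7 carbon, 2 nitrogen, 3 oxygen; one six-membered aromatic ring of carbon only) in place of a group of 10 heavy atoms (7 carbon, 1 nitrogen, 1 sulfur, 1 chlorine; one six-membered aromatic ring of carbon only), on an amine nitrogen in a ring. The group that enters is a (4-nitrophenyl)carbamoyl group, and it sits on an amine nitrogen in a ring, three ring bonds from the ring nitrogen and from the ring atom that bears a large group. Going by the values given here, no step between two measured compounds exists for this kind of change, so no direction can be read from the numbers in hand. A step of this size is expected to stay within the scatter, and the number for compound 3 in this assay is estimated at 20%, with a range from 5% to 40%, which means an expected step of a number 2 percentage points higher from compound 1 to compound 3 (within the scatter).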

Compound 3, a percentage reported as inhibition, at one concentration (the size of the read-out at that concentration, not a potency): 19%
Compound 3: the middle estimate sits 1 percentage points above what was measured, within the range that was stated.
By their numbers in this assay, from the lowest: compounds 1, 3 and 2 (each within the scatter of the next).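

In this assay, going by these compounds alone, putting the (4-nitrophenyl)carbamoyl group on the amine nitrogen in the ring, in place of the group carried by compound 1, gives a number 1 percentage points higher from compound 1 to compound 3 (within the scatter) and is the first step measured at this position. The exchange is not a small one, since sulfur and chlorine leave, two nitrogen-free-of-ring oxygen-bearing features enter with the nitro group, and the hydrogen-bond acceptors go from 1 to 3, yet the reading cannot be set apart from that of compound 1. Within this single pair, then, these differences in the group on the ring nitrogen leave no mark on the read-out beyond the usual scatter, and no measurement is at hand that would explain this.

Within the data shown here, the two compounds do not separate the exchange of sulfur for oxygen from the exchange of chlorine for the nitro group, and compound 2 differs from both in more than one place, so no step to it can be read. Also open, on these data alone, is how the reading would respond at this ring nitrogen to a different kind of group, such as a carboxylic acid on the aromatic ring or a longer chain in place of that ring.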